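Freeing the oxygen of compound 3

The source may hold more compounds than are shown below. What is called first, only, known or untested is meant among the compounds shown, and "the series" means these compounds.

Values so far in an ADME assay on PA-1 cells (Homo sapiens) for cytotoxicity, read by MTT assay, with a stated time of 72 h; a lower number here means a stronger inhibitor, a higher number a weaker inhibitor:
compound 1 `COc1ccc(C2=C(c3cc(OC)c(OC)c(OC)c3)C(=O)C(O)C2)cc1` gives < 1 ug/mL as a limit
compound 2 `COc1ccc(C2=C(c3cc(OC)c(OC)c(OC)c3)C(=O)C(O)C2)cc1NC(=O)c1ccccc1` gives > 100 ug/mL as a limit
compound 3 `COc1ccc(C2=C(c3cc(OC)c(OC)c(OC)c3)C(=O)C(O[SiH2]C(C)(C)C)C2)cc1OC(C)C` gives 7.1 ug/mL

In this assay, among the compounds with values here, compound 3 gives 7.1 ug/mL and holds the only exact number here. The other two values are limits.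

The unmeasured compound 4 (`COc1ccc(C2=C(c3cc(OC)c(OC)c(OC)c3)C(=O)C(O)C2)cc1OC(C)C`) differs from compound 3 in one place: a hydrogen atom in place of a group of 5 heavy atoms (4 carbon, 1 silicon; no ring), on an oxygen on a saturated carbon.

Within the data shown here, the one measured step, an at least 100-fold higher number from compound 1 to compound 2 (2.00 log units; beyond the scatter), is large. Among the measured compounds shown here, it is benzamido in place of hydrogen on an aromatic carbon, so it leaves that oxygen untouched and shows only that a single change can move this number far. Compound 1 carries the same hydrogen on that oxygen and reports the limit < 1 ug/mL. Compound 2 carries it too and reports the limit > 100 ug/mL. The hydrogen alone therefore settles nothing, and only a modest fall in the number is expected, with wide doubt. The expected change is a 2.4-fold lower number from compound 3 to compound 4 (0.37 log units; beyond the scatter). For compound 4 the estimate is 3 ug/mL, with an expected range from 0.6 ug/mL to 20 ug/mL.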

Compound 4, half-maximal inhibitory concentration: > 100 ug/mL
Compound 4 gave a limit, no number; the forecaster's own chance of this, stated with the estimate: 25%; middle value at least 33-fold (1.52 log units) from the limit.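

On this oxygen on a saturated carbon, replacing the silicon-bearing group with hydrogen is far from a small change in this assay: an at least 14-fold higher number from compound 3 to compound 4 (1.14 log units; beyond the scatter). The free oxygen-hydrogen group therefore does not guarantee a low number on its own, and with that group kept, adding isopropoxy in place of hydrogen on an aromatic carbon gives an at least 100-fold higher number from compound 1 to compound 4 (2.00 log units; beyond the scatter). Both steps are only minimum sizes because compound 4 reached a limit of the assay, not an exact number: the limit of > 100 ug/mL in this assay, at which 2 of the 4 values shown sit.

The step between compound 2 and compound 4 cannot be read, since both values are limits. On these data alone, it remains open whether a smaller group on that oxygen, such as a methyl ether or an acetate ester, would bring a measurable number, and how an amine would behave in place of isopropoxy on the aromatic carbon.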